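Varying the group on the carbonyl carbon of the shared core

The source may hold more compounds than are shown below. What is called first, only, known or untested is meant among the compounds shown, and "the series" means these compounds.

The series keeps the shared core of compound 1 `Cc1nn(C(=O)C2CC2)c(N)c1-c1ccc(Cl)c(Cl)c1` and varies only the group on the carbonyl carbon. In an assay on Sf9 cells for inhibition of mitogen-activated protein kinase kinase kinase 14 (Homo sapiens), read by ADP-Glo, with a stated time of 60 min (a higher number here means a weaker inhibitor, a lower number a stronger inhibitor), compound 1 gives 24300 nM. Among the measured compounds shown here, compound 2 `Cc1nn(C(=O)c2ccncc2)c(N)c1-c1ccc(Cl)c(Cl)c1` gives 58200 nM in this assay, the highest of the two numbers so far; the step of a 2.4-fold higher number from compound 1 to compound 2 (0.38 log units; beyond the scatter) is modest but beyond the scatter. Compound 3 `CCNC(=O)n1nc(C)c(-c2ccc(Cl)c(Cl)c2)c1N` carries the change (ethylamino in place of pyridin-4-yl on a carbonyl carbon). For the measured compounds named here, the only measured step that bears on this place is a 2.4-fold higher number from compound 1 to compound 2 (0.38 log units; beyond the scatter), which shows that the group on the carbonyl carbon moves the number modestly and that pyridin-4-yl gave the higher one. Nothing measured shows how ethylamino behaves at this place. A modest step downward, back toward the level of compound 1, is therefore expected, a 2.3-fold lower number from compound 2 to compound 3 (0.37 log units; beyond the scatter). The estimate for compound 3 in this assay is 25000 nM, expected to lie between 8000 nM and 80000 nM.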

Compound 3, half-maximal inhibitory concentration: > 100000 nM
Compound 3: only a limit was reported; the forecaster's own chance of this, stated with the estimate: 5%; middle value at least 4.0-fold (0.60 log units) from the limit.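

In this assay compound 3 is reported only as a limit, > 100000 nM, so ethylamino has no exact number at this place: the limit of > 100000 nM in this assay, at which 1 of the 3 values shown sits. Against cyclopropyl the change still reads clearly, with an at least 4.1-fold higher number from compound 1 to compound 3 (0.61 log units; beyond the scatter), so ethylamino does not return to the level of compound 1. Against pyridin-4-yl the reading is weaker, with an at least 1.7-fold higher number from compound 2 to compound 3 (0.23 log units; that floor lies within the scatter), so only the cyclopropyl comparison establishes a difference beyond the scatter.

Ethylamino differs from both earlier groups in having no ring and in bringing a hydrogen-bond donor, and the compounds shown leave open which of these goes with the higher number. Dimethylamino, with no ring and no donor, and cyclopropylamino, with both, would separate the two at this place.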